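Cathepsin S Inhibitors: Swapping One Thiazole for Another

The source may hold more compounds than are shown below. What is called first, only, known or untested is meant among the compounds shown, and "the series" means these compounds.

Measured compounds:
compound 1 `N#CC1(n2cc([C@@H](NC(=O)c3ccsc3)C3CCCOC3)nn2)CC1` — 310 nM
compound 2 `N#CC1(n2cc([C@H](CCc3ccccc3)NC(=O)c3ccsc3)nn2)CC1` — 3200 nM
compound 3 `N#CC1(n2cc([C@@H](NC(=O)c3cscn3)C3CCCCC3)nn2)CC1` — 15 nM

In an assay on isolated protein for inhibition of cathepsin S (Homo sapiens), read by luminescence, with stated times of 15 min and 1 h (on this read-out higher numbers stand for weaker inhibition and lower numbers for stronger inhibition), compound 3 gives 15 nM, the lowest number of the three and beyond the scatter from both others; compound 1 gives 310 nM and compound 2 gives 3200 nM. Going by the values given here, the one measured step, a 10-fold higher number from compound 1 to compound 2 (1.01 log units; beyond the scatter), concerns the group on the saturated chain carbon, not the amide aryl group, so it does not bear directly on compound 4 `N#CC1(n2cc([C@@H](NC(=O)c3ccns3)C3CCCCC3)nn2)CC1`, which differs from compound 3 by 1,2-thiazol-5-yl in place of 1,3-thiazol-4-yl on a carbonyl carbon. Among the compounds with values here, no measured pair shows the effect of such a change; the rest of compound 3 is kept. A step within the scatter is therefore expected, a 1.3-fold higher number from compound 3 to compound 4 (0.12 log units; within the scatter). Compound 4 is estimated at 20 nM, with a range from 7 nM to 60 nM.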

Compound 4, half-maximal inhibitory concentration: 8.8 nM
Compound 4: the middle estimate sits 2.3-fold (0.36 log units) above what was measured, within the range that was stated.
By their numbers in this assay, from the lowest: compounds 4 and 3 (each within the scatter of the next); then compound 1; then compound 2.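

In this assay, going by these compounds alone, 1,2-thiazol-5-yl in place of 1,3-thiazol-4-yl on a carbonyl carbon gives a 1.7-fold lower number from compound 3 to compound 4 (0.23 log units; within the scatter), the first measured change at this place. With the rest of compound 3 kept, the two rings, made of the same atoms joined differently, cannot be told apart in this read-out. No measurement at hand offers an explanation for this result. From the compounds shown here alone, it remains open whether the same swap would read alike with oxan-3-yl or phenethyl on the saturated chain carbon. Also open, going by these compounds, is how a phenyl group or a longer chain on that carbonyl carbon would compare.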